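Two Halogens Exchanged on the Way from Compound 2 to Compound 3

The source may report more compounds than this note shows. Statements on the series, on what has been measured and on what is new or still open speak of the compounds shown alone.

Of the compounds shown here, two have so far been measured in a functional assay on BT-549 cells (Homo sapiens) for cytotoxicity, read by sulforhodamine B assay, with a stated time of 48 h, tested at 0.01 uM; on this read-out higher numbers stand for a weaker effect at the one concentration tested and lower numbers for a stronger effect. Compound 1 `COc1ccc(-c2cc(/C=C/C(=O)c3ccc(N)cc3)[nH]n2)cc1` gives 92% in this assay, and compound 2 `COc1cc(-c2cc(/C=C/C(=O)c3ccc(Cl)c(Cl)c3)[nH]n2)cc(OC)c1OC` gives 89%. The two numbers lie within the scatter of each other, so compound 2 stands beside compound 1 rather than apart from it, and both point to a weak effect at the single concentration tested. Compound 3 `COc1cc(-c2cc(/C=C/C(=O)c3ccc(F)c(F)c3)[nH]n2)cc(OC)c1OC` has not yet been measured. It differs from compound 2 in one place: 3,4-difluorophenyl in place of 3,4-dichlorophenyl on a carbonyl carbon. Only the two halogens change; the ring, the count of heavy atoms and the absence of donors, acceptors and charge are kept. Among the compounds with values here, no step between two measured compounds shows how such an exchange moves the read-out, and the two measured compounds share neither this ring nor the other end of the molecule. The expected step of a number 2 percentage points higher from compound 2 to compound 3 (within the scatter) is none beyond the scatter, in no particular direction, because compound 2 gives 89% and compound 1 gives a number within the scatter of it. Compound 3 is therefore expected to give 91% in this assay, with a range from 80% to 100%.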

Compound 3, a percentage reported as activity, at one concentration (the size of the read-out at that concentration, not a potency): 101%
For compound 3 the middle estimate is 10 percentage points below the measured one, outside the stated range (above it).
By their numbers in this assay, from the lowest: compounds 2, 1 and 3 (each within the scatter of the next, the first and the last beyond it).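

In this assay, within the data shown here, the exchange of 3,4-dichlorophenyl for 3,4-difluorophenyl on a carbonyl carbon gives the first step that can be read at this place, a number 12 percentage points higher from compound 2 to compound 3 (beyond the scatter), a modest move towards a weaker effect at the one concentration tested. The read-out therefore responds to the two halogens alone, with the ring, the count of heavy atoms, the absence of donors and acceptors and the absence of charge all unchanged, something compound 1 and compound 2 could not show because they differ in more than one place. Of this pair, the dichlorophenyl of compound 2 goes with the stronger effect, but nothing shown gives a reason for the difference.

A single step cannot say whether the read-out follows the halogen in any regular way, and a dibromophenyl, a bis(trifluoromethyl)phenyl or an unsubstituted phenyl at this place would be needed to test that. On these data alone, it also remains open whether the step would persist with a different group at the other end of the molecule, or at any other concentration.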